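The compounds below may be only part of what the source reports. "The series", "measured", "known", "first", "only" and "open" are said of these compounds alone.

Compound 2 `CC(C)CC(=O)O[C@H]1C[C@@H](C)C=C2C=C[C@H](C)[C@H](CC[C@@H]3C[C@@H](O)CC(=O)O3)C21` stands at one end of this short series: in an assay for inhibition of 3-hydroxy-3-methylglutaryl-coenzyme A reductase (Rattus norvegicus) (on this read-out lower numbers stand for stronger inhibition and higher numbers for weaker inhibition), compound 2 gives 5.4 nM, the highest of the two numbers measured, while compound 1 `CCC(CC)(CC)C(=O)O[C@H]1C[C@@H](C)C=C2C=C[C@H](C)[C@H](CC[C@@H]3C[C@@H](O)CC(=O)O3)C21` gives 1.4 nM. Compound 3 `CC(CC(=O)O[C@H]1C[C@@H](C)C=C2C=C[C@H](C)[C@H](CC[C@@H]3C[C@@H](O)CC(=O)O3)C21)C(F)(F)F` differs from compound 2 by a single change: trifluoromethyl in place of methyl on a saturated chain carbon bound to two saturated chain carbons. Within the data shown here, the only measured step, a 3.9-fold higher number from compound 1 to compound 2 (0.59 log units; beyond the scatter), concerns the same side chain, where the larger branched group went with the lower number; it involves no trifluoromethyl, so it bears on the new step only loosely. Because a 3.9-fold higher number from compound 1 to compound 2 (0.59 log units; beyond the scatter) shows that a larger chain came with a lower number, any step for compound 3 is expected to point the same way, but the data give no firm ground for more than a small one. Compound 3 is therefore estimated at 4 nM (range 1.5 nM to 12 nM), a step of a 1.4-fold lower number from compound 2 to compound 3 (0.13 log units; within the scatter) that is expected to stay within the scatter.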

Compound 3, half-maximal inhibitory concentration: 3.5 nM
For compound 3 the middle estimate is 1.1-fold (0.06 log units) above the measured one; low and high end bracket the measured number.
By their numbers in this assay, from the lowest: compound 1; then compounds 3 and 2 (each within the scatter of the next).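

In this assay, putting trifluoromethyl in place of methyl on this saturated chain carbon gives a 1.5-fold lower number from compound 2 to compound 3 (0.19 log units; within the scatter) and so leaves no change that can be told from the scatter, even though the entering group carries more heavy atoms than the one it replaces. The 1,1-diethylpropyl group still differs from the new side chain, with a 2.5-fold higher number from compound 1 to compound 3 (0.40 log units; beyond the scatter) on that swap, so compound 1 keeps the lowest number of the three. Nothing available here explains these numbers.

Still open, going by these compounds, is whether this chain carbon would accept a hydroxyl group, an amine or a single fluorine equally well. On these data alone, it is also open whether an ethyl or a longer chain at this place would bring the number closer to that of compound 1.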